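The compounds below may be only part of what the source reports. "The series", "measured", "known", "first", "only" and "open" are said of these compounds alone.

Measured compounds:
- compound 1 `COc1ccc(-c2[nH]c3ccccc3c2/C=C(\C#N)S(=O)(=O)c2ccccc2)cc1`: 10700 nM
- compound 2 `COc1ccc2[nH]c(-c3ccccc3)c(C=C(C#N)C#N)c2c1`: 30000 nM
- compound 3 `CCOC(=O)C(=Cc1c(-c2ccccc2)[nH]c2ccccc12)C(=O)OCC`: 7500 nM

In a functional assay on UACC-257 cells (Homo sapiens) for inhibition, read by sulforhodamine B assay, with a stated time of 48 h (on this read-out higher numbers stand for weaker inhibition of growth and lower numbers for stronger inhibition of growth), compound 1 gives 10700 nM, the second highest of the three numbers. Compound 3 gives 7500 nM, which lies within the usual scatter of compound 1, so no order between the two can be stated. Compound 2 gives 30000 nM, a higher number than compound 1, and that gap is beyond the scatter.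

The next compound, compound 4 `COc1ccc(-c2[nH]c3ccc(OC)cc3c2/C=C(\C#N)S(=O)(=O)c2ccccc2)cc1`, differs from compound 1 by methoxy in place of hydrogen on an aromatic carbon. Within the data shown here, no pair of measured compounds differs by this change alone, so no measured step is available for it; compound 2 carries a methoxy on its fused ring but also differs from compound 1 elsewhere. On the information at hand the expected step in this assay is a 1.2-fold lower number from compound 1 to compound 4 (0.08 log units; within the scatter), which lies within the scatter and points in no clear direction. For compound 4 the estimate in this assay is 9000 nM, with a range from 3000 nM to 30000 nM.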

Compound 4, concentration for 50% growth inhibition: 46100 nM
Compound 4: the middle estimate sits 5.1-fold (0.71 log units) below what was measured; the measured number lies above the stated range.
By their numbers in this assay, from the lowest: compounds 3 and 1 (each within the scatter of the next); then compounds 2 and 4 (each within the scatter of the next).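

In this assay, a 4.3-fold higher number from compound 1 to compound 4 (0.63 log units; beyond the scatter) gives the series its first step from a single change, and it shows that this carbon, meta to a fused ring and para to a fused ring, is not neutral for growth inhibition. Methoxy in place of hydrogen here weakens inhibition of growth beyond the scatter, so this part of the core of compound 1 affects the read-out. Nothing available accounts for the size or direction of this step.

From the compounds shown here alone, it remains open whether the weakening is specific to methoxy or extends to other replacements of hydrogen on this carbon, such as a fluorine, a hydroxyl or an amine. Also open, going by these compounds, is whether the same change would have a similar effect on compound 3, which carries a different group on the core.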